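Swapping Hydroxy for Amino: An Expected Loss of Potency

A few compounds are considered here, and "the series" means these few. Any claim that something is new, unique, unknown or untested is made for them only; others in the source may bear on it.

Compound 1 `Oc1ccc(/C=C/c2cccc(O)c2)cc1` gives 6.9 ug/mL in a functional assay on HT-29 cells (Homo sapiens) for inhibition, read by MTT assay, with a stated time of 2 days; on this read-out higher numbers stand for weaker inhibition and lower numbers for stronger inhibition. Compound 2 `Nc1cccc(/C=C/c2ccc(O)cc2)c1` gives 51 ug/mL in this assay, and the step of a 7.4-fold higher number from compound 1 to compound 2 (0.87 log units; beyond the scatter) goes with amino in place of hydroxy on an aromatic carbon. Compound 3 `COc1ccccc1/C=C/c1ccc(O)cc1` gives 24 ug/mL in this assay; the difference between its core and that of compound 1 is not broken down here. Compound 4 `COc1ccccc1/C=C/c1ccc(N)cc1` has not yet been measured and differs from compound 3 by amino in place of hydroxy on an aromatic carbon. This is the same kind of change as that between compound 1 and compound 2, but not the same: in compound 2 the group sits meta to a group of 9 heavy atoms, whereas in compound 4 it sits para to a large group. Compound 4 is expected to give 120 ug/mL in this assay, between 40 ug/mL and 300 ug/mL, because the step of a 7.4-fold higher number from compound 1 to compound 2 (0.87 log units; beyond the scatter) weakened inhibition. The expected step is a 5.0-fold higher number from compound 3 to compound 4 (0.70 log units; beyond the scatter), estimated somewhat smaller than the earlier one given the different place.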

Compound 4, half-maximal inhibitory concentration: 22 ug/mL
Beside the measured number, compound 4's estimate is 5.5-fold (0.74 log units) above it; measured number below the stated range.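

In this assay, amino in place of hydroxy does not carry the same result from one core to the other: the same change on two cores in this assay, a 7.4-fold higher number (0.87 log units; beyond the scatter) from compound 1 to compound 2 and a 1.1-fold lower number (0.04 log units; within the scatter) from compound 3 to compound 4, 8.1-fold (0.91 log units) apart, beyond the scatter of two such steps The change here gives a 1.1-fold lower number from compound 3 to compound 4 (0.04 log units; within the scatter), so the weakening seen on the core of compound 1 does not follow from the swap alone. Within the data shown here, with only two pairs, the data do not show whether the gap goes with where the group sits or with the rest of the core, and they give no rule for any further core.

The compounds shown leave open how a dimethylamino group or a carboxylic acid in that place on the core of compound 3 would read in this assay. They also leave open whether the amino group would give a step beyond the scatter on a third core.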